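Swapping chlorines for fluorines on the ketone-bearing ring

The source may hold more compounds than are shown below. What is called first, only, known or untested is meant among the compounds shown, and "the series" means these compounds.

Measured compounds:
compound 1, `COc1ccc(-c2cc(/C=C/C(=O)c3ccc(N)cc3)[nH]n2)cc1`, 95%
compound 2, `COc1cc(-c2cc(/C=C/C(=O)c3ccc(N)cc3)[nH]n2)cc(OC)c1OC`, 97%
compound 3, `COc1cc(-c2cc(/C=C/C(=O)c3ccc(Cl)c(Cl)c3)[nH]n2)cc(OC)c1OC`, 95%

All three share a core in which a chain carrying a carbonyl links a pyrazole-type unit to a second aromatic ring. In a functional assay on PC-3 cells (Homo sapiens) for cytotoxicity, read by sulforhodamine B assay, with a stated time of 48 h, tested at 0.01 uM (a higher number here means a weaker effect of the compound at the concentration tested, a lower number a stronger effect), compound 1 gives 95%, compound 2 gives 97% and compound 3 gives 95%. Compound 3 is level with compound 1 at the digits shown and lies within the scatter of compound 2, so the three numbers cannot be told apart.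

Going by the values given here, the only single-change step measured is a number 2 percentage points lower from compound 2 to compound 3 (within the scatter), meaning that replacing the 4-aminophenyl by a 3,4-dichlorophenyl on the carbonyl carbon left the read-out where it was.

Compound 4, `COc1cc(-c2cc(/C=C/C(=O)c3ccc(F)c(F)c3)[nH]n2)cc(OC)c1OC`, differs from compound 3 in one place: 3,4-difluorophenyl in place of 3,4-dichlorophenyl on a carbonyl carbon. The step from compound 2 to compound 3 is the one that bears on this; it changed the group on the carbonyl carbon far more drastically than a chlorine-to-fluorine swap and still stayed within the scatter. No step beyond the scatter is therefore expected here, and the estimated step is no change at the digits printed from compound 3 to compound 4 (within the scatter). Compound 4 is expected to give about 95%, between 85% and 102%.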

Compound 4, a percentage reported as activity, at one concentration (the size of the read-out at that concentration, not a potency): 98%
Compound 4: middle estimate off by 3 percentage points, on the low side; low and high end bracket the measured number.
By their numbers in this assay, from the lowest: compounds 1, 3, 2 and 4 (each within the scatter of the next).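

In this assay, exchanging the halogens on the ring held by the carbonyl carbon gives a number 3 percentage points higher from compound 3 to compound 4 (within the scatter), and the comparison with the amine-bearing ring gives a number 1 percentage points higher from compound 2 to compound 4 (within the scatter). With the same core, three groups on this carbonyl carbon (4-aminophenyl, 3,4-dichlorophenyl and 3,4-difluorophenyl) can now be compared, and none can be told apart from the others, so neither the kind of halogen nor the swap of the amine for either pair of halogens produces a step beyond the scatter. Nothing available here offers an explanation for these numbers, so the flat result stands only as an observation.

Each number describes a single low concentration. Going by these compounds, the read-out is not a potency, and it remains open whether these compounds would separate at higher concentrations. On these data alone, it also remains open whether a different kind of group on the carbonyl carbon, such as a carboxylic acid or a longer alkyl chain in place of the aromatic ring, would move the read-out beyond the scatter.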